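The source may report more compounds than this note shows. Statements on the series, on what has been measured and on what is new or still open speak of the compounds shown alone.

Compound 1 `O=C(Nc1cccc(Cl)c1)c1ccc(/N=N\c2c[nH]c3ccccc23)cc1` gives 80000 nM in a functional assay on HCT-116 cells (Homo sapiens) for inhibition, read by MTT assay, with a stated time of 72 h; a higher number here means a weaker inhibitor, a lower number a stronger inhibitor. Compound 2 `COc1ccccc1NC(=O)c1ccc(/N=N\c2c[nH]c3ccccc23)cc1` gives 122000 nM in this assay, and compound 3 `O=C(Nc1ccc([N+](=O)[O-])cc1)c1ccc(/N=N\c2c[nH]c3ccccc23)cc1` gives 156000 nM. Compound 3 holds the highest of the three numbers, yet both gaps to it lie within the scatter: a 2.0-fold higher number from compound 1 to compound 3 (0.29 log units; within the scatter) and a 1.3-fold higher number from compound 2 to compound 3 (0.11 log units; within the scatter). Compound 4 `O=C(Nc1ccc(Cl)cc1)c1ccc(/N=N\c2c[nH]c3ccccc23)cc1` is not yet measured; it differs from compound 3 by chloro in place of nitro on an aromatic carbon. The step that bears on this is the one exchanging a 3-chlorophenyl for a 4-nitrophenyl, a 2.0-fold higher number from compound 1 to compound 3 (0.29 log units; within the scatter), within the scatter, as was a 1.5-fold higher number from compound 1 to compound 2 (0.18 log units; within the scatter). Three different amide substituents thus moved the number very little, so compound 4 is expected to land close to compound 3, with an estimated step of a 1.6-fold lower number from compound 3 to compound 4 (0.19 log units; within the scatter), not beyond the scatter. Compound 4 is estimated at 100000 nM, with a range of 50000 nM to 200000 nM.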

Compound 4, half-maximal inhibitory concentration: 187000 nM
Beside the measured number, compound 4's estimate is 1.9-fold (0.27 log units) below it; low and high end bracket the measured number.
By their numbers in this assay, from the lowest: compounds 1, 2, 3 and 4 (each within the scatter of the next, the first and the last beyond it).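

Within this assay, replacing the nitro group with a chloro group stays within the scatter, a 1.2-fold higher number from compound 3 to compound 4 (0.08 log units; within the scatter), as does 4-chlorophenyl in place of 2-methoxyphenyl, a 1.5-fold higher number from compound 2 to compound 4 (0.19 log units; within the scatter). For the compounds shown here, exchanging 3-chlorophenyl for 4-chlorophenyl gives the first modest step beyond the scatter, a 2.3-fold higher number from compound 1 to compound 4 (0.37 log units; beyond the scatter), so two compounds with the same substituent name but different ring placement are separated here. Nothing measured on these compounds accounts for this gap. All amide substituents shown are substituted phenyl rings, so it remains open whether an amine, a carboxylic acid or a longer chain on that ring would bring the number down.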